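A Chloro for Methyl Swap at the Limit

This account rests on a few compounds, and the source may have more. Where it says the series, first, only, none or still open, it means among the compounds named here.

Compound 1 `c1ccc(-c2nnc(COc3ccc(-c4nnco4)cc3)o2)cc1` and compound 2 `Cc1ccc(-c2nnc(COc3ccc(-c4nnco4)cc3)o2)cc1` share one core. In a functional assay on MCF7 cells (Homo sapiens) for cytotoxicity, read by MTT assay, with a stated time of 48 h (on this read-out lower numbers stand for stronger inhibition and higher numbers for weaker inhibition), compound 1 gives > 50000 nM, which is a limit and not a number. In this assay compound 2 gives > 50000 nM, again a limit. Among the measured compounds shown here, compound 2 therefore has no measured number, and the only other value beside it is also a limit. Both compounds stand at the limit of > 50000 nM in this assay, at which 2 of the 2 values shown sit.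

Compound 3 `Clc1ccc(-c2nnc(COc3ccc(-c4nnco4)cc3)o2)cc1` differs from compound 2 by chloro in place of methyl on an aromatic carbon, para to a large group, or 4-methylphenyl to 4-chlorophenyl.

For the measured compounds named here, only one measured step bears on this change, methyl in place of hydrogen on the same ring. Since that step is a step that the two limits leave unreadable from compound 1 to compound 2, it offers no size to carry over, and no step beyond the scatter is expected in this assay, in either direction. The expected change is a number no higher from compound 2 to compound 3 (the limit leaves the size open). Compound 3 is most likely to be reported as a limit again. If a number is reported, compound 3 is estimated at 50000 nM, with an expected range from 20000 nM to 100000 nM.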

Compound 3, half-maximal inhibitory concentration: 45200 nM
Compound 3: the middle estimate sits 1.1-fold (0.04 log units) above what was measured, and the stated range covers the measured number.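

In this assay, the swap to 4-chlorophenyl gives an at least 1.1-fold lower number from compound 2 to compound 3 (0.04 log units; that floor lies within the scatter), and chloro in place of hydrogen on the same aromatic carbon gives an at least 1.1-fold lower number from compound 1 to compound 3 (0.04 log units; that floor lies within the scatter). Compound 3 alone among the three compounds carries a number and not a limit, so chloro, para to a large group, is the only substituent shown at this position that gives a readable value. The two steps are floors and not sizes, and the step from hydrogen to methyl still cannot be read, so the series still rests largely on limits: the limit of > 50000 nM in this assay, at which 2 of the 3 values shown sit.

The compounds shown leave open how far the true values of compound 1 and compound 2 lie from that limit, and therefore whether chloro truly separates from hydrogen or methyl by more than the scatter or merely lands close to the edge of the readable range. They also leave open how other groups on this aromatic carbon would read, such as fluoro, bromo, methoxy, an amine or a carboxylic acid, and whether any of them would give a number clearly lower than that of compound 3.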